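Amide aryl swap on shared core: cytotoxicity notes

The source may hold more compounds than are shown below. What is called first, only, known or untested is meant among the compounds shown, and "the series" means these compounds.

Measured compounds:
- compound 1 `Cn1cnnc1SCCc1nnc(SCC(=O)Nc2ccc([N+](=O)[O-])cc2)o1`: > 500 ug/mL
- compound 2 `Cn1cnnc1SCCc1nnc(SCC(=O)Nc2ccc(F)cc2)o1`: > 500 ug/mL
- compound 3 `Cn1cnnc1SCCc1nnc(SCC(=O)Nc2nc3ccccc3s2)o1`: > 500 ug/mL

In an ADME assay on NIH3T3 cells (Mus musculus) for cytotoxicity, read by MTT assay, with a stated time of 24 h (on this read-out higher numbers stand for weaker inhibition and lower numbers for stronger inhibition), compound 1 gives > 500 ug/mL, which is a limit of the assay and not a number. Compound 2 likewise gives > 500 ug/mL, a limit. Compound 3 gives > 500 ug/mL, again a limit. All three measured values therefore sit at the limit of > 500 ug/mL in this assay, at which 3 of the 3 values shown sit, and none of the three steps between them can be read: a step that the two limits leave unreadable from compound 1 to compound 2, a step that the two limits leave unreadable from compound 1 to compound 3 and a step that the two limits leave unreadable from compound 2 to compound 3 are all unreadable in size and direction.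

Compound 3 thus stands at the assay limit alongside the other two, with no resolved difference between any pair.

Compound 4 `Cn1cnnc1SCCc1nnc(SCC(=O)Nc2ccccc2)o1` differs from compound 3 by phenyl in place of 1,3-benzothiazol-2-yl on an amide-type nitrogen. Among the measured compounds shown here, the steps that bear on this change are the two that already exchange the amide aryl group, from compound 1 to compound 3 and from compound 2 to compound 3, and both are unreadable because the values on either side sit at the limit of > 500 ug/mL in this assay, at which 3 of the 3 values shown sit. For the measured compounds named here, no step in the set beyond the scatter is available for the amide-aryl position.

The expectation for compound 4 is therefore a value at the limit as well, estimated at 600 ug/mL with a range from 300 ug/mL to 1500 ug/mL. The expected step that the limit leaves unreadable from compound 3 to compound 4 is none beyond the scatter.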

Compound 4, half-maximal inhibitory concentration: > 500 ug/mL
Compound 4: no number, only a limit (the forecaster's own chance of this, stated with the estimate: 85%); the middle value lies beyond the limit too.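

In this assay, the steps linking compound 4 with compound 1, compound 2 and compound 3 cannot be read, because all four compounds give only a limit and not a number: the limit of > 500 ug/mL in this assay, at which 4 of the 4 values shown sit.

The compounds shown leave open how far any of the four lies beyond that limit, and whether the amide-nitrogen group on the shared core affects this read-out at all.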